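Bromo for trifluoromethyl: a lipophilicity estimate

The source may hold more compounds than are shown below. What is called first, only, known or untested is meant among the compounds shown, and "the series" means these compounds.

Measured compounds:
Compound 1 `CC(C)(C)n1ncc(OCc2nnc(-c3ccccc3F)o2)c(Cl)c1=O` gives 2.89 in a physicochemical assay for lipophilicity; on this read-out higher numbers stand for higher lipophilicity and lower numbers for lower lipophilicity.
Compound 2 `CC(C)(C)n1ncc(OCc2nnc(-c3ccc(C(F)(F)F)cc3)o2)c(Cl)c1=O` gives 3.66 in this assay.
Compound 3 `CC(C)(C)n1ncc(OCc2nnc(-c3cc(F)c(F)c(F)c3F)o2)c(Cl)c1=O` gives 3.18 in this assay.

Of the compounds shown here, three sharing one core have been measured in this assay. Compound 2 stands highest of the three. Its nearest neighbour is compound 3, whose value lies lower by a gap beyond the usual scatter; furthest away is compound 1, lower still, again beyond the scatter. Among the compounds with values here, the two values of compound 3 and compound 1 show that the more fluorine-bearing of the two sits higher, but with only three compounds no broader pattern can be claimed.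

The next compound, compound 4 `CC(C)(C)n1ncc(OCc2nnc(-c3ccc(Br)cc3)o2)c(Cl)c1=O`, differs from compound 2 in one place: bromo in place of trifluoromethyl on an aromatic carbon. Within the data shown here, nothing among the measured compounds isolates this exact change, so the expected size of the step rests on the structural difference alone. For compound 4 a step in this assay is expected to be small, a number 0.06 log units lower from compound 2 to compound 4 (within the scatter), and not beyond the scatter in either direction.

Compound 4 is therefore estimated at 3.6 in this assay, with a range from 3.3 to 3.9.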

Compound 4, partition coefficient: 3.21
Beside the measured number, compound 4's estimate is 0.39 log units above it; the whole stated range lies above it.
By their numbers in this assay, from the lowest: compounds 1, 3 and 4 (each within the scatter of the next, the first and the last beyond it); then compound 2.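

In this assay, within the data shown here, bromo in place of trifluoromethyl on this aromatic carbon is the first change on the shared core that can be read in one place, and it gives a number 0.45 log units lower from compound 2 to compound 4 (beyond the scatter) on this read-out. The exchange of one fluorine-bearing group for a single bromine atom therefore moves the number by more than repeat measurements would, so on this core the two groups cannot be treated as equivalent in this assay. The second step, with 4-bromophenyl in place of 2-fluorophenyl, gives a number 0.32 log units higher from compound 1 to compound 4 (beyond the scatter) and places compound 4 on the other side of compound 1 from where compound 2 alone could show the bromo group's standing, yet no measurement at hand bears on why either step has its size.

On these data alone, what a nitrile, a methoxy group or a carboxylic acid would give on this same aromatic carbon remains open, so the two groups seen here cannot yet be set on any wider scale. As far as these compounds go, it also remains open whether bromo in place of trifluoromethyl would take a step of the same size on another carbon of this ring, or on a different core.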